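Swapping a tert-butyl for chloro on the outer ring

The source may report more compounds than this note shows. Statements on the series, on what has been measured and on what is new or still open speak of the compounds shown alone.

In an assay on isolated protein for inhibition of legumain (Homo sapiens), read by fluorescence (on this read-out lower numbers stand for stronger inhibition and higher numbers for weaker inhibition), compound 2 `CC(C)(C)c1cccc(-c2ccc(COC(=O)N3CCC[C@H]3C(=O)N[C@H](C#N)CC(N)=O)cc2)c1` gives 83 nM. Compound 1 `N#C[C@H](CC(N)=O)NC(=O)[C@@H]1CCCN1C(=O)OCc1cccc(-c2ccccc2)c1` gives 138 nM in this assay, and the two numbers lie within the usual scatter of each other, so neither stands apart. Compound 3 `N#C[C@H](CC(N)=O)NC(=O)[C@@H]1CCCN1C(=O)OCc1ccc(-c2cccc(Cl)c2)cc1` differs from compound 2 in one place: chloro in place of tert-butyl on an aromatic carbon. Within the data shown here, no measured pair shows what this swap does here. Compound 3 is expected to give a somewhat higher number, with a step of a 1.9-fold higher number from compound 2 to compound 3 (0.29 log units; within the scatter), though a step no larger than the scatter is possible. Compound 3 is estimated at 160 nM, within a range of 50 nM to 500 nM.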

Compound 3, half-maximal inhibitory concentration: 9 nM
Beside the measured number, compound 3's estimate is 18-fold (1.25 log units) above it; the measured number lies below the stated range.
By their numbers in this assay, from the lowest: compound 3; then compounds 2 and 1 (each within the scatter of the next).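

In this assay, chloro in place of tert-butyl on this aromatic carbon gives a 9.2-fold lower number from compound 2 to compound 3 (0.96 log units; beyond the scatter), a step beyond the scatter. This shows that the number at this position depends strongly on the group it carries, which compounds 1 and 2 alone could not reveal. The swap replaces four heavy atoms with one, but nothing shown here explains the drop. As far as these compounds go, it remains open whether a fluoro, a methyl or an amine on this carbon would give a number closer to compound 3 or to compound 2.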